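The source may hold more compounds than are shown below. What is called first, only, known or untested is meant among the compounds shown, and "the series" means these compounds.

Measured so far, in a functional assay on HeLa cells (Homo sapiens) for inhibition, read by CCK-8 assay, with a stated time of 48 h; a higher number here means a weaker inhibitor, a lower number a stronger inhibitor:

Compound 1 `COc1ccc(Oc2ccccc2-c2ccsc2S(=O)(=O)N2CCN(C(=S)Nc3cc(C(F)(F)F)cc(C(F)(F)F)c3)CC2)cc1OC`: a limit only, > 50000 nM.
Compound 2 `O=C(NCCNS(=O)(=O)c1ccc(-c2ccccc2Oc2ccc([N+](=O)[O-])c([N+](=O)[O-])c2)s1)Nc1cc(C(F)(F)F)cc(C(F)(F)F)c1`: a limit only, > 50000 nM.
Compound 3 `Cc1ccc(-c2ccsc2S(=O)(=O)NCCNC(=O)Nc2ccc([N+](=O)[O-])cc2)c(Oc2ccc(O)c(O)c2)c1`: a limit only, > 20000 nM.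

Compound 2 stands at a limit in this assay, not at a number; the same holds for every value shown, two of them at the limit of > 50000 nM in this assay, at which 2 of the 3 values shown sit, and one at the limit of > 20000 nM in this assay, at which 1 of the 3 values shown sits. Among the compounds with values here, no step between measured compounds can be drawn from such limits.

Compound 4 `O=C(NCCNS(=O)(=O)c1ccc(-c2ccccc2OCc2cccc(O)c2)s1)Nc1cc(C(F)(F)F)cc(C(F)(F)F)c1` differs from compound 2 by 3-hydroxybenzyl in place of 3,4-dinitrophenyl on an oxygen on an aromatic ring. Whether this change moves the result beyond the scatter cannot be read from the measured compounds, since none of them gives a number. The step from compound 2 to compound 4 is expected to be an at least 1.1-fold lower number from compound 2 to compound 4 (0.04 log units; that floor lies within the scatter), that is, essentially none beyond the scatter. For compound 4 the estimate in this assay is 45000 nM, with a range from 8000 nM to 250000 nM, and a further limit is the likelier outcome.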

Compound 4, half-maximal inhibitory concentration: 17300 nM
For compound 4 the middle estimate is 2.6-fold (0.42 log units) above the measured one; measured number inside the range.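

In this assay, 3-hydroxybenzyl in place of 3,4-dinitrophenyl on an oxygen on an aromatic ring gives an at least 2.8-fold lower number from compound 2 to compound 4 (0.46 log units; beyond the scatter). Compound 4 is thus the first compound here with a number rather than a limit, and this position is shown to respond to a change of group. The size of the step is only a floor, as compound 2 stands at a limit: the limit of > 50000 nM in this assay, at which 2 of the 4 values shown sit.

Within the data shown here, the single exchange replaces the whole group, so the contributions of the hydroxyl and of the loss of both nitro groups cannot be separated. From the compounds shown here alone, whether an amine or a carboxylic acid in place of the hydroxyl would lower the number further remains open.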